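The source may report more compounds than this note shows. Statements on the series, on what has been measured and on what is new or still open speak of the compounds shown alone.

Measured so far:

compound 1, `C[C@@H]1CN(c2cccc(NS(=O)(=O)c3ccc(-c4ccccn4)s3)c2)C[C@H](C)N1`: 0.8
compound 2, `C[C@@H]1CN(c2ccc(F)c(NS(=O)(=O)c3ccc(-c4ccccn4)s3)c2)C[C@H](C)N1`: 0.8
compound 3, `COc1ccc(F)c(-c2ccc(S(=O)(=O)Nc3cc(N4C[C@@H](C)N[C@@H](C)C4)ccc3OC)cc2)c1`: 1.2

All three were run in a functional assay for agonist activity at growth hormone secretagogue receptor type 1 (Homo sapiens), read by FLIPR; on this read-out higher numbers stand for larger maximal responses and lower numbers for smaller maximal responses. Compound 1 gives 0.8 and compound 2 gives 0.8; the two share a core and differ in one place, namely (hydrogen in place of fluoro on an aromatic carbon), and the step of no change at the digits printed from compound 2 to compound 1 (within the scatter) shows that this exchange did nothing to the maximal response. Compound 3 stands apart on a different core; compound 3 gives 1.2, which is the highest of the three and lies beyond the scatter from both compound 1 and compound 2. The difference between the core of compound 3 and the core of compound 2 is not broken down here.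

Compound 4, `COc1cccc(-c2ccc(S(=O)(=O)Nc3cc(N4C[C@@H](C)N[C@@H](C)C4)ccc3OC)cc2)c1`, has not yet been run in this assay. It differs from compound 3 in one place: hydrogen in place of fluoro on an aromatic carbon. For the measured compounds named here, this is the same kind of change as the one from compound 2 to compound 1, but the surroundings differ: in compound 2 the fluoro sits para to a 3,5-dimethylpiperazin-1-yl group, whereas in compound 3 it sits para to a methoxy group, on a ring ortho to a large group in both cases.

Going by the values given here, for compound 4 the expected step is no change at the digits printed from compound 3 to compound 4 (within the scatter), because the only measured instance of this kind of change, no change at the digits printed from compound 2 to compound 1 (within the scatter), left the maximal response where it was. The estimate for compound 4 in this assay is therefore 1.2, expected to fall between 1 and 1.4.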

Compound 4, intrinsic activity: the largest response reached, as a fraction of the reference agonist's: 1
Beside the measured number, compound 4's estimate is 0.20 above it, and the stated range covers the measured number.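

In this assay, the exchange of 2-fluoro-5-methoxyphenyl for 3-methoxyphenyl gives a number 0.20 lower from compound 3 to compound 4 (beyond the scatter), so on this core the fluoro cannot be replaced by hydrogen without a measurable, though modest, loss of maximal response. Setting this beside the earlier pair shows that hydrogen in place of fluoro on an aromatic carbon does not carry over from one core to the other as a fixed increment: the same change on two cores in this assay, no change at the digits printed (within the scatter) from compound 2 to compound 1 and a number 0.20 lower (beyond the scatter) from compound 3 to compound 4, 0.20 apart, beyond the scatter of two such steps What this does not show is which of the differences between the two cores accounts for the gap, since each core supplies a single pair, and two pairs give neither a general rule for the series nor a typical size for the step.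

The compounds shown leave open how a chloro, a methyl or a nitrile on the same aromatic carbon would read in this assay, and whether any of these would hold the maximal response of the fluoro compound on either core. Also open, from the compounds shown here alone, is whether the step would persist if the methoxy group on that ring gave way to an ethoxy group, a hydroxyl or a carboxylic acid.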